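Does Dropping the Methoxy Raise Inhibition Again?

A few compounds are considered here, and "the series" means these few. Any claim that something is new, unique, unknown or untested is made for them only; others in the source may bear on it.

Three compounds have been measured so far:

Compound 1 `O=C(Nc1ccc(Cl)cc1)NS(=O)(=O)c1cc2ccccc2o1`: 84%
Compound 2 `COc1ccc2oc(S(=O)(=O)NC(=O)Nc3ccc(Cl)cc3)cc2c1`: 25%
Compound 3 `COc1cc(S(=O)(=O)NC(=O)Nc2ccc(Cl)cc2)cc2ccoc12`: 51%

These numbers come from a functional assay on the whole organism (Mus musculus) for inhibition, at a dose of 150 mg/kg by the oral route; a lower number here means less inhibition, a higher number more inhibition at the dose given (going by the name of the read-out). Compound 2 and compound 1 differ in one place, (hydrogen in place of methoxy on an aromatic carbon), and this change made a number 59 percentage points higher from compound 2 to compound 1 (beyond the scatter). Compound 3 has the same atoms as compound 2, joined differently; the difference between the two cores is not broken down here.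

Compound 4 `O=C(Nc1ccc(Cl)cc1)NS(=O)(=O)c1ccc2occc2c1` has not yet been measured. It stands to compound 3 as compound 1 stands to compound 2: hydrogen in place of methoxy on an aromatic carbon. The surroundings are not identical, though. In compound 2 the methoxy sits meta to a fused ring and para to a fused ring, whereas in compound 3 it sits ortho to a fused ring, meta to a fused ring and meta to a large group, so this is the same kind of change rather than the same change.

Compound 4 is therefore expected to move by a number 24 percentage points higher from compound 3 to compound 4 (beyond the scatter) in this assay. That expectation rests on the earlier step, a number 59 percentage points higher from compound 2 to compound 1 (beyond the scatter), tempered by the different surroundings and the small number of compounds. The estimated value for compound 4 in this assay is 75%, expected to fall between 50% and 95%.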

Compound 4, a percentage reported as inhibition, in the whole organism at one dose (the size of the read-out at that dose, not a potency): 100%
Estimate against measurement, compound 4: 25 percentage points below; the whole stated range lies below it.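

Taking away the methoxy and leaving a hydrogen raises the number on a second core in this assay (a number 49 percentage points higher from compound 3 to compound 4 (beyond the scatter)). Going by these compounds alone, this is one change on two cores, with the methoxy in different surroundings, so it gives only two examples and says nothing about a third core or about why the number rises. It also rests on one oral dose in one test, so it does not show how the compounds would compare at other doses. Even so, within these four compounds the change carried over from one core to the other in both direction and size: the same change on two cores in this assay, a number 59 percentage points higher (beyond the scatter) from compound 2 to compound 1 and a number 49 percentage points higher (beyond the scatter) from compound 3 to compound 4, 10 percentage points apart, within the scatter of two such steps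

The compounds shown have only methoxy or hydrogen at these places, so it remains open what an ethoxy group, a fluorine or an amine would do there. All four also carry the same chlorine, which leaves open what a methyl group or a carboxylic acid in its place would do.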